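Series notes: ethoxy leaves, hydrogen enters, compound 1 to 4

The source may report more compounds than this note shows. Statements on the series, on what has been measured and on what is new or still open speak of the compounds shown alone.

Compound 1 `CCOc1ccccc1OCCSC(=S)N[C@H]1CCOC1=O` is the reference point of these notes. In a functional assay on MGC-803 cells (Homo sapiens) for antiproliferative activity, read by MTT assay, with a stated time of 72 h (a lower number here means a stronger inhibitor, a higher number a weaker inhibitor), compound 1 gives > 64000 nM, which is a limit of the assay and not a number. Within the data shown here, nothing measured so far differs from compound 1 in only one place, so no single-point step is available. Compound 3 `O=C1OCC[C@@H]1NC(=S)SCCOc1cccc2ccccc12` keeps the same core with the ether leading to a larger aromatic part; in this assay compound 3 gives > 64000 nM, again a limit rather than a number. Compound 2 `COc1ccccc1/C=C/C(=O)c1ccc(OCC(=O)N[C@H]2CCOC2=O)cc1` is built on a different skeleton with an amide link, and in this assay compound 2 gives 39400 nM, the only numerical reading shown. Two of the three values thus sit at the limit of > 64000 nM in this assay, at which 2 of the 3 values shown sit.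

The change to compound 4 `O=C1OCC[C@@H]1NC(=S)SCCOc1ccccc1` is hydrogen in place of ethoxy on an aromatic carbon. Among the measured compounds shown here, no measured step of this kind exists in the set, so only an expectation can be stated. Because compound 1 gives > 64000 nM, a step of no more than the scatter is expected, and the limit is expected to persist. The step from compound 1 to compound 4 is estimated at a step that the limit leaves unreadable from compound 1 to compound 4. Compound 4 is expected at 70000 nM, within 30000 nM to 200000 nM.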

Compound 4, half-maximal inhibitory concentration: 53800 nM
Compound 4: the middle estimate sits 1.3-fold (0.11 log units) above what was measured; low and high end bracket the measured number.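

In this assay compound 4 gives 53800 nM, so with hydrogen on this aromatic carbon, ortho to a large group, the core of compound 1 yields a number and ethoxy is not needed for a numerical reading. In the same assay, this assay, compound 1 gives > 64000 nM, which is a limit of the assay and not a number. The change of ethoxy to hydrogen therefore reads only as an at least 1.1-fold lower number from compound 1 to compound 4 (0.07 log units; that floor lies within the scatter), and its true size remains unknown because one end of the step rests on a limit: the limit of > 64000 nM in this assay, at which 2 of the 4 values shown sit.

Open, from the compounds shown here alone, is how a methoxy, a hydroxyl or an amine on the same aromatic carbon would compare with hydrogen in compound 4, and whether any of them would give a step beyond the scatter. Also open, going by these compounds, is whether a longer chain in place of the ethoxy would keep the reading at a limit, as in compound 1, or return a number as in compound 4.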